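Replacing the tert-butyl pyrimidine of compound 2 with ethoxypyridine

The compounds below may be only part of what the source reports. "The series", "measured", "known", "first", "only" and "open" are said of these compounds alone.

Two compounds of the series carry numbers in an assay on blood for inhibition of C-X-C chemokine receptor type 3 (Homo sapiens), with a stated time of 30 min; on this read-out lower numbers stand for stronger inhibition and higher numbers for weaker inhibition. Compound 1 `CCOc1ncc(-c2nc(C(F)(F)F)sc2N2CCN(C(=O)Cn3nc(C)nc3C)[C@H](C)C2)cn1` gives 364 nM. Among the measured compounds shown here, compound 2 `Cc1nc(C)n(CC(=O)N2CCN(c3sc(C(F)(F)F)nc3-c3cnc(C(C)(C)C)nc3)C[C@H]2C)n1` gives 1160 nM, the higher of the two numbers; its nearest neighbour is compound 1, and the single measured step, a 3.2-fold higher number from compound 1 to compound 2 (0.50 log units; beyond the scatter), lies between them.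

Compound 3 `CCOc1ccc(-c2nc(C(F)(F)F)sc2N2CCN(C(=O)Cn3nc(C)nc3C)[C@H](C)C2)cn1` has no number yet. It differs from compound 2 by 6-ethoxypyridin-3-yl in place of 2-(tert-butyl)pyrimidin-5-yl on an aromatic carbon. For the measured compounds named here, only the step from compound 1 to compound 2 bears on this change: there, tert-butyl in place of ethoxy on an aromatic carbon raised the number by a modest amount. The move to compound 3 puts an ethoxy group back, but on a six-membered ring with one ring nitrogen rather than two; for the loss of that ring nitrogen the series holds no measured comparison. The expectation is therefore a lowering of the number roughly undoing the earlier rise, with the ring-nitrogen change left as an open uncertainty, a 2.9-fold lower number from compound 2 to compound 3 (0.46 log units; beyond the scatter). Compound 3 is estimated at 400 nM, within a range of 150 nM to 1100 nM.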

Compound 3, half-maximal inhibitory concentration: 887 nM
Compound 3: the middle estimate sits 2.2-fold (0.35 log units) below what was measured, within the range that was stated.
By their numbers in this assay, from the lowest: compound 1; then compounds 3 and 2 (each within the scatter of the next).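

In this assay the ethoxy group alone does not carry the lower number of compound 1: 6-ethoxypyridin-3-yl in place of 2-(tert-butyl)pyrimidin-5-yl gives a 1.3-fold lower number from compound 2 to compound 3 (0.12 log units; within the scatter) and so leaves the two groups unseparated at this position on the ring. With the ethoxy group held constant, the series now has its first direct reading of the ring itself, as 6-ethoxypyridin-3-yl in place of 2-ethoxypyrimidin-5-yl gives a 2.4-fold higher number from compound 1 to compound 3 (0.39 log units; beyond the scatter) and this step lies beyond the scatter. Among the compounds shown here, at this position, then, the lowest number so far depends on the ethoxy group and the pyrimidine ring occurring together, since changing either one takes the value away from that of compound 1, and no supporting measurement accounts for this.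

Still open, from the compounds shown here alone, is whether tert-butyl on the pyridine ring would follow the same trend, which would show if the ring matters equally with both substituents. Also open, going by these compounds, is how the 2-substituted pyrimidin-5-yl ring responds to other groups in place of ethoxy, such as a dimethylamino group or a longer alkoxy chain like butoxy.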